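Methyl on the ring oxygen: urea pair and amide follow-up

A few compounds are considered here, and "the series" means these few. Any claim that something is new, unique, unknown or untested is made for them only; others in the source may bear on it.

Measured so far, in a functional assay on OVCAR-5 cells (Homo sapiens) for inhibition, read by sulforhodamine B assay, with a stated time of 48 h, tested at 10 uM; a higher number here means a weaker effect of the compound at the concentration tested, a lower number a stronger effect:
compound 1, `O=C(Nc1cccc(-n2cc(-c3ccncc3)c(-c3cc(O)cc(Cl)c3)n2)c1)Nc1ccc(Cl)c(Cl)c1`, gives -2.26%
compound 2, `COc1cc(Cl)cc(-c2nn(-c3cccc(NC(=O)Nc4ccc(Cl)c(Cl)c4)c3)cc2-c2ccncc2)c1`, gives 37.8%
compound 3, `O=C(Nc1cccc(-n2cc(-c3ccncc3)c(-c3cc(O)cc(Cl)c3)n2)c1)c1cc(C(F)(F)F)cc(C(F)(F)F)c1`, gives 70.7%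

Compound 1 and compound 2 share one core and differ only by methyl in place of hydrogen on an oxygen on an aromatic ring. That single change gave a number 40.1 percentage points higher from compound 1 to compound 2 (beyond the scatter), a step that lies beyond the scatter. Compound 3 carries a different core; the difference between the core of compound 1 and the core of compound 3 is not broken down here. In this assay compound 3 stands highest of the three numbers, with compound 2 nearest and compound 1 furthest, both gaps beyond the scatter.

Compound 4, `COc1cc(Cl)cc(-c2nn(-c3cccc(NC(=O)c4cc(C(F)(F)F)cc(C(F)(F)F)c4)c3)cc2-c2ccncc2)c1`, is the not yet measured partner of compound 3. It differs from compound 3 by methyl in place of hydrogen on an oxygen on an aromatic ring, the same change as between compound 1 and compound 2, and the place of the change is worded the same for both pairs. The hydroxy to methoxy change is thus made twice in this set, once on each core.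

For compound 4 the expected step is a number 17.3 percentage points higher from compound 3 to compound 4 (beyond the scatter), because compound 3 already gives 70.7% and the read-out has little room left upward. This expected step is smaller than a number 40.1 percentage points higher from compound 1 to compound 2 (beyond the scatter). For compound 4 a value of about 88% is expected, with a plausible range from 65% to 105%.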

Compound 4, a percentage reported as activity, at one concentration (the size of the read-out at that concentration, not a potency): 83%
Beside the measured number, compound 4's estimate is 5 percentage points above it; measured number inside the range.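

In this assay the change from hydroxy to methoxy, here 3-chloro-5-hydroxyphenyl to 3-chloro-5-methoxyphenyl, gives a number 12.3 percentage points higher from compound 3 to compound 4 (beyond the scatter). The direction of the change therefore carries over from one core to the other in these two pairs, but its size does not: the same change on two cores in this assay, a number 40.1 percentage points higher (beyond the scatter) from compound 1 to compound 2 and a number 12.3 percentage points higher (beyond the scatter) from compound 3 to compound 4, 27.8 percentage points apart, beyond the scatter of two such steps

This shows only that methyl on the oxygen went with a higher number, meaning a weaker effect at the concentration tested, on both cores. It does not show a rule for other cores in the series, and with two pairs whose cores are not broken down, no part of the core can be tied to the difference in step size.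

Still open, on these data alone, is whether an ethyl group on the same oxygen, or an amine in place of the hydroxy, would move the number in the same direction on either core. Also open, as far as these compounds go, is whether the two steps would keep their relation at other concentrations, as this read-out gives the size of the effect at a single concentration and not a potency.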